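This account rests on a few compounds, and the source may have more. Where it says the series, first, only, none or still open, it means among the compounds named here.

Measured so far:
Compound 1, `COc1cc(-c2cc(/C=C/C(=O)c3ccc(Cl)c(Cl)c3)[nH]n2)cc(OC)c1OC`, gives 91% in a functional assay on MDA-MB-468 cells (Homo sapiens) for cytotoxicity, read by sulforhodamine B assay, with a stated time of 48 h, tested at 0.1 uM; a lower number here means a stronger effect, a higher number a weaker effect of the compound at the concentration tested.
Compound 2, `COc1ccc(C(=O)/C=C/c2cc(-c3cc(OC)c(OC)c(OC)c3)n[nH]2)cc1`, gives 88% in this assay.

Going by the values given here, only two numbers are known here. Among the compounds with values here, compound 2 stands next to compound 1, and the one step between them, a number 3 percentage points lower from compound 1 to compound 2 (within the scatter), lies within the scatter, so the two compounds cannot be told apart on these numbers.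

Compound 3, `COc1cc(-c2cc(/C=C/C(=O)c3ccc(F)c(F)c3)[nH]n2)cc(OC)c1OC`, has not yet been measured. It differs from compound 2 in one place: 3,4-difluorophenyl in place of 4-methoxyphenyl on a carbonyl carbon. Within the data shown here, the only measured step that bears on this is the exchange of one aromatic group on the carbonyl carbon between compound 1 and compound 2, which gave a number 3 percentage points lower from compound 1 to compound 2 (within the scatter). Since that swap, from a halogenated ring to the methoxy ring, moved nothing beyond the scatter, the return to a halogenated ring in compound 3 is expected to move little as well.

For compound 3 the expected step is a number 2 percentage points higher from compound 2 to compound 3 (within the scatter), within the scatter. Compound 3 is therefore estimated at 90% in this assay, within a range of 80% to 100%.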

Compound 3, a percentage reported as activity, at one concentration (the size of the read-out at that concentration, not a potency): 94%
For compound 3 the middle estimate is 4 percentage points below the measured one; measured number inside the range.
By their numbers in this assay, from the lowest: compounds 2, 1 and 3 (each within the scatter of the next).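

Replacing 4-methoxyphenyl with 3,4-difluorophenyl on the carbonyl carbon gives a number 6 percentage points higher from compound 2 to compound 3 (within the scatter) in this assay, and replacing 3,4-dichlorophenyl with 3,4-difluorophenyl gives a number 3 percentage points higher from compound 1 to compound 3 (within the scatter). Three different aromatic groups have now been compared at this position, and none can be told apart from the others, whether the ring carries two fluorines, two chlorines or one methoxy group. No measurement available here offers an explanation for this result.

These compounds leave open whether the three groups would separate at a concentration other than the single one tested. From the compounds shown here alone, it also remains open whether a group of a different kind on the carbonyl carbon, such as a phenyl ring bearing an amine or a carboxylic acid, or a longer chain, would produce a step beyond the scatter.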